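A ring in place of a chain on compound 2

The source may report more compounds than this note shows. Statements on the series, on what has been measured and on what is new or still open speak of the compounds shown alone.

In a functional assay on A-431 cells (Homo sapiens) for cytotoxicity, read by MTT assay (on this read-out lower numbers stand for stronger inhibition and higher numbers for weaker inhibition), compound 1 `C=CC(=O)Nc1ccc(OC)c(Nc2ncc(Cl)c(N3CCc4sccc4C3)n2)c1` gives 90900 nM, while compound 2 `C=CC(=O)Nc1cc(Nc2ncc(Cl)c(N3CCc4sccc4C3)n2)c(OC)cc1N(C)CCN(C)C` gives 5490 nM. Placing (2-(dimethylamino)ethyl)(methyl)amino in place of hydrogen on an aromatic carbon accounts for a 17-fold lower number from compound 1 to compound 2 (1.22 log units; beyond the scatter). Compound 3 `COc1cc(N(C)CCN(C)C)c(NC(=O)C=C(C)C)cc1Nc1ncc(Cl)c(N2CCc3sccc3C2)n1`, carrying 2-methylprop-1-en-1-yl in place of vinyl on a carbonyl carbon, reaches only a limit of the assay, > 50000 nM. That change amounts to an at least 9.1-fold higher number from compound 2 to compound 3 (0.95 log units; beyond the scatter). Compound 2 therefore holds the lowest number in the series.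

Compound 4 `C=CC(=O)Nc1cc(Nc2ncc(Cl)c(N3CCc4sccc4C3)n2)c(OC)cc1N1CCN(C)CC1` has not yet been measured. It differs from compound 2 by one change, 4-methylpiperazin-1-yl in place of (2-(dimethylamino)ethyl)(methyl)amino on an aromatic carbon: 4-methylpiperazin-1-yl replaces (2-(dimethylamino)ethyl)(methyl)amino on an aromatic carbon, ortho to a (vinylcarbonyl)amino group. Among the measured compounds shown here, no measured step tests this swap directly. The closest evidence is compound 2 itself, whose a 17-fold lower number from compound 1 to compound 2 (1.22 log units; beyond the scatter) shows that this substituent position matters. Since the counted features stay the same, only a small rise is expected in this assay, probably within the scatter. The expected change is a 1.3-fold higher number from compound 2 to compound 4 (0.11 log units; within the scatter). The estimate for compound 4 is 7000 nM, with an expected range from 2500 nM to 20000 nM.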

Compound 4, half-maximal inhibitory concentration: > 50000 nM
Compound 4: only a limit was reported; the forecaster's own chance of this, stated with the estimate: 8%; at least 7.1-fold (0.85 log units) between middle value and limit.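

In this assay, among the compounds shown here, the earlier compounds showed only that this aromatic carbon responds to a substituent, with (2-(dimethylamino)ethyl)(methyl)amino giving a 17-fold lower number from compound 1 to compound 2 (1.22 log units; beyond the scatter), whereas the new result shows that the form of the group also counts: closing the chain into 4-methylpiperazin-1-yl, with the same heavy atoms and hydrogen-bond counts, gives an at least 9.1-fold higher number from compound 2 to compound 4 (0.95 log units; beyond the scatter). For compound 4, > 50000 nM is a limit of the assay, so the size of this step is only bounded: the limit of > 50000 nM in this assay, at which 2 of the 4 values shown sit. The step from hydrogen to 4-methylpiperazin-1-yl, with compound 1 as its starting point, cannot be read.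

The compounds shown leave open whether any ring at this position behaves like 4-methylpiperazin-1-yl. A morpholin-4-yl group, or a 4-(dimethylamino)piperidin-1-yl group, which keeps a ring but moves the outer amine, would be needed to test this.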